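Second fluorine on the aryl group: compound 1 to compound 3

The source may report more compounds than this note shows. Statements on the series, on what has been measured and on what is new or still open speak of the compounds shown alone.

Among the measured compounds shown here, in a functional assay on HCT-116 cells (Homo sapiens) for inhibition, read by MTT assay, with a stated time of 48 h (on this read-out lower numbers stand for stronger inhibition and higher numbers for weaker inhibition), compound 1 (`Cc1nnsc1CO/N=C/c1c(C)nn(C)c1Oc1ccc(F)cc1`) gives 30200 nM, the higher of the two numbers measured so far. For the measured compounds named here, its only measured neighbour, compound 2 (`Cc1nnsc1CO/N=C/c1c(C)nn(C)c1Oc1cccc(F)c1F`), gives 6560 nM and carries 2,3-difluorophenyl in place of 4-fluorophenyl on an oxygen on an aromatic ring.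

The unmeasured compound 3 (`Cc1nnsc1CO/N=C/c1c(C)nn(C)c1Oc1cc(F)cc(F)c1`) keeps the core of compound 1 and takes 3,5-difluorophenyl in place of 4-fluorophenyl at the same place: 3,5-difluorophenyl in place of 4-fluorophenyl on an oxygen on an aromatic ring.

Going by the values given here, one measured step bears on this change: a 4.6-fold lower number from compound 1 to compound 2 (0.66 log units; beyond the scatter). It is modest but beyond the scatter, and it is the only measured case of a difluorophenyl replacing 4-fluorophenyl. Among the compounds with values here, the two fluorines sit differently in compound 3, and no measured compound carries 3,5-difluorophenyl, so that step offers only partial guidance. A move in the same direction is expected in this assay, though a smaller one.

The expected step is a 2.3-fold lower number from compound 1 to compound 3 (0.37 log units; beyond the scatter). The estimate for compound 3 is 13000 nM, with an expected range of 5500 nM to 30000 nM.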

Compound 3, half-maximal inhibitory concentration: 8120 nM
Beside the measured number, compound 3's estimate is 1.6-fold (0.20 log units) above it, and the stated range covers the measured number.
By their numbers in this assay, from the lowest: compounds 2 and 3 (each within the scatter of the next); then compound 1.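

Compound 2 is no longer the only case of a difluorophenyl group giving a lower number than 4-fluorophenyl at this position, on an oxygen on an aromatic ring: in this assay there is a 3.7-fold lower number from compound 1 to compound 3 (0.57 log units; beyond the scatter) as well. Both difluorophenyl compounds shown therefore follow the same direction against compound 1, and none of the three compounds goes against it, although that pattern rests on only two steps. The two difluorophenyl groups cannot be separated in this assay, with a 1.2-fold higher number from compound 2 to compound 3 (0.09 log units; within the scatter), so 2,3-difluorophenyl and 3,5-difluorophenyl read alike here, and nothing measured in this set explains the shared step away from 4-fluorophenyl.

All three compounds carry only fluorine on the phenyl group at this place, which leaves open how unsubstituted phenyl, 3,5-dichlorophenyl or 3,5-dimethoxyphenyl would read in this assay. Also open, on these data alone, are whether 3,4,5-trifluorophenyl would extend the step seen with the difluorophenyl groups, and whether the same step would hold if the shared core were changed elsewhere.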